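Shortening the Amine Side Chain: Compound 3 to Compound 4

The source may hold more compounds than are shown below. What is called first, only, known or untested is meant among the compounds shown, and "the series" means these compounds.

Compound 1 `Cc1cn([C@@H]2O[C@H](CO[Si](C)(C)C(C)(C)C)[C@@]3(OS(=O)(=O)C=C3NC(=O)c3ccccc3)[C@H]2O[Si](C)(C)C(C)(C)C)c(=O)n(C)c1=O` gives 4900 nM in a functional assay on MT4 cells (Homo sapiens); a higher number here means that more compound is tolerated, a lower number that less compound is tolerated.
Compound 2 `Cc1cn([C@@H]2O[C@@H]3COC(=O)[C@]3(OS(C)(=O)=O)[C@H]2O)c(=O)[nH]c1=O` reaches only a limit in this assay, >= 250000 nM.
Compound 3 `Cc1cn([C@@H]2O[C@H](CO[Si](C)(C)C(C)(C)C)[C@@]3(OS(=O)(=O)C=C3NCC(=O)C(N)=O)[C@H]2O[Si](C)(C)C(C)(C)C)c(=O)n(C)c1=O` gives 9590 nM in this assay.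

Among the two numbers measured in this assay, compound 3 holds the higher one, and its nearest neighbour is compound 1: the step of a 2.0-fold higher number from compound 1 to compound 3 (0.29 log units; within the scatter) exchanged benzoyl for (carbamoylcarbonyl)methyl on an amine nitrogen and stayed within the scatter. The remaining value, that of compound 2, is a limit and not a number.

Compound 4 `Cc1cn([C@@H]2O[C@H](CO[Si](C)(C)C(C)(C)C)[C@@]3(OS(=O)(=O)C=C3NCC(N)=O)[C@H]2O[Si](C)(C)C(C)(C)C)c(=O)n(C)c1=O` is not yet measured. It differs from compound 3 in one place: amino in place of carbamoyl on a carbonyl carbon. Read one bond further out, the (carbamoylcarbonyl)methyl of compound 3 becomes carbamoylmethyl in compound 4.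

Going by the values given here, only one measured step touches the same amine substituent, the step from compound 1 to compound 3, and it lay within the scatter. Nothing measured here separates a carbamoyl from an amino on that carbonyl carbon. The expected step of a 1.1-fold lower number from compound 3 to compound 4 (0.03 log units; within the scatter) is therefore none beyond the scatter. Compound 4 is estimated to give 9000 nM in this assay, with a range from 3500 nM to 23000 nM.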

Compound 4, half-maximal cytotoxic concentration: 14900 nM
The estimate for compound 4 lay 1.7-fold (0.22 log units) below the measured number; the measured number falls inside the stated range.
By their numbers in this assay, from the lowest: compounds 1, 3 and 4 (each within the scatter of the next, the first and the last beyond it). At a limit, above all of these: compound 2.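

The exchange of carbamoyl for amino on a carbonyl carbon gave a 1.6-fold higher number from compound 3 to compound 4 (0.19 log units; within the scatter) in this assay, so this change at the amine substituent stayed within the scatter, as did a 2.0-fold higher number from compound 1 to compound 3 (0.29 log units; within the scatter). The wider comparison is what adds something new: replacing benzoyl with carbamoylmethyl on the amine nitrogen gave a 3.0-fold higher number from compound 1 to compound 4 (0.48 log units; beyond the scatter), a modest step and the first at this nitrogen to lie beyond the scatter, so the substituents on this nitrogen can make a measurable difference in how much compound is tolerated. Nothing measured here accounts for that difference.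

The compounds shown leave open whether a carboxylic acid, a longer alkyl chain or an unsubstituted amine at this nitrogen would carry the number further in the same direction or reverse it. As far as these compounds go, all three numbers at this nitrogen also come from one shared core in this assay, and whether the same exchanges would give similar steps on a different core remains unknown.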